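A few compounds are considered here, and "the series" means these few. Any claim that something is new, unique, unknown or untested is made for them only; others in the source may bear on it.

The two measured compounds share one core. Compound 1 `Nc1scc(CN2CCN(c3ccc([N+](=O)[O-])cc3)CC2)c1C(=O)c1ccc(Cl)cc1` carries 4-nitrophenyl on the amine nitrogen in the ring, and in a functional assay on CHO cells with adenosine receptor A1 (Homo sapiens) as the target, read by cAMP accumulation and immunoassay, with a stated time of 6 min, tested at 0.1 uM (on this read-out higher numbers stand for a weaker effect at the one concentration tested and lower numbers for a stronger effect), compound 1 gives -13%. Compound 2 `Nc1scc(CN2CCN(c3ccncc3)CC2)c1C(=O)c1ccc(Cl)cc1` carries pyridin-4-yl there instead, and in this assay compound 2 gives 1.4%, the higher of the two numbers. Among the measured compounds shown here, the only step in hand is a number 14.4 percentage points higher from compound 1 to compound 2 (beyond the scatter). Compound 3 `Nc1scc(CN2CCN(c3ccc(F)c(Cl)c3)CC2)c1C(=O)c1ccc(Cl)cc1` differs from compound 2 in one place: 3-chloro-4-fluorophenyl in place of pyridin-4-yl on an amine nitrogen in a ring. For the measured compounds named here, no measured step covers this particular swap, so the expectation rests loosely on the other substituent tried on that nitrogen: compound 1, with its -13%, sits lower than compound 2. A step back toward lower numbers is therefore expected, of modest size at most and possibly not beyond the scatter, a number 6.4 percentage points lower from compound 2 to compound 3 (within the scatter). Compound 3 is accordingly estimated to give -5% in this assay, within a range from -25% to 15%.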

Compound 3, a percentage reported as activity, at one concentration (the size of the read-out at that concentration, not a potency): -21%
Beside the measured number, compound 3's estimate is 16 percentage points above it; the measured number falls inside the stated range.
By their numbers in this assay, from the lowest: compounds 3 and 1 (each within the scatter of the next); then compound 2.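

Exchanging the pyridin-4-yl for 3-chloro-4-fluorophenyl on the amine nitrogen in the ring gives, in this assay, a number 22.4 percentage points lower from compound 2 to compound 3 (beyond the scatter), so this position responds to a second substituent as well as to the first. The change from 4-nitrophenyl to 3-chloro-4-fluorophenyl gives a number 8 percentage points lower from compound 1 to compound 3 (within the scatter), so the two substituted phenyl groups cannot be told apart here, and among these three compounds only the pyridin-4-yl of compound 2 stands apart. Nothing at hand explains this difference.

On these data alone, whether an unsubstituted phenyl or a pyridin-3-yl would fall with compound 2 or with compound 3 remains open, as does the outcome with a short alkyl chain or an acetyl on that nitrogen. The read-out at one concentration also leaves the potencies of all three compounds unknown.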